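The source may report more compounds than this note shows. Statements on the series, on what has been measured and on what is new or still open speak of the compounds shown alone.

The three measured compounds share one core and differ only in their side groups. Compound 3 `Cc1ccc(COc2cc(O)c3c(=O)cc(-c4ccccc4)oc3c2OCCCCN2CCN(C)CC2)cc1` gives 3200 nM in a functional assay on A549 cells (Homo sapiens) for cytotoxicity, read by MTT assay, with a stated time of 72 h (a higher number here means a weaker inhibitor, a lower number a stronger inhibitor), the highest of the three numbers seen so far. Compound 1 `COc1c(OCCCCN2CCN(C)CC2)cc(O)c2c(=O)cc(-c3ccc(Br)cc3)oc12` gives 2130 nM in this assay, which lies within the scatter of compound 3. Compound 2 `CN(C)CCCCOc1c(OCc2ccccc2)cc(O)c2c(=O)cc(-c3ccccc3)oc12` gives 1090 nM in this assay, a lower number than compound 3 that lies beyond the scatter; those two compounds differ in more than one place, so no single change can be read from that pair.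

Compound 4 `CN1CCN(CCCCOc2c(OCc3ccco3)cc(O)c3c(=O)cc(-c4ccccc4)oc23)CC1` differs from compound 3 in one place: furan-2-yl in place of 4-methylphenyl on a saturated chain carbon bound to an oxygen on an aromatic ring. Among the compounds with values here, no measured pair shows this exchange on its own, so its effect is not known from these data. With compound 1 and compound 3 sitting close together despite different side groups, the expected step in this assay from compound 3 to compound 4 is a 1.3-fold lower number from compound 3 to compound 4 (0.11 log units; within the scatter), none beyond the scatter. Compound 4 is therefore estimated at 2500 nM, with a range from 1100 nM to 6000 nM.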

Compound 4, half-maximal inhibitory concentration: 3600 nM
The estimate for compound 4 lay 1.4-fold (0.16 log units) below the measured number; measured number inside the range.
By their numbers in this assay, from the lowest: compounds 2, 1, 3 and 4 (each within the scatter of the next, the first and the last beyond it).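

At this position, on a saturated chain carbon bound to an oxygen on an aromatic ring, the exchange of 4-methylphenyl for furan-2-yl can now be read on its own: in this assay it gives a 1.1-fold higher number from compound 3 to compound 4 (0.05 log units; within the scatter). The earlier compounds shown here offered no such pair. The result shows that this position accepts a five-membered aromatic ring with a hetero atom and a hydrogen-bond acceptor in place of a six-membered carbon ring, with no change beyond the scatter. Nothing measured here offers an explanation for this result. Going by these compounds, whether a pyridin-3-yl ring or a carboxylic acid on this carbon would move the number stays open. So does whether the same exchange would read alike on a compound carrying the dimethylamino chain of compound 2.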